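This account rests on a few compounds, and the source may have more. Where it says the series, first, only, none or still open, it means among the compounds named here.

Measured so far:
compound 1 `N=C(N)c1ccc2cc(-c3cccc(OCCCOc4ccccc4)c3)oc2c1`: 19800 nM
compound 2 `N=C(N)c1ccc2cc(-c3cccc(OCCCCOc4ccccc4)c3)oc2c1`: 7600 nM

Going by the values given here, in an ADME assay on L6 cells (Rattus norvegicus) for cytotoxicity, read by resazurin assay, with a stated time of 70 h (on this read-out higher numbers stand for weaker inhibition and lower numbers for stronger inhibition), compound 2 gives 7600 nM, the lower of the two numbers, with compound 1 as its only neighbour at a higher value. Compound 3 `N=C(N)c1ccc2cc(-c3cccc(OCCCCCOc4ccccc4)c3)oc2c1` differs from compound 2 by phenoxymethyl in place of phenoxy on a saturated chain carbon, four bonds along the chain from an oxygen on an aromatic ring. Among the compounds with values here, the one measured step that bears on it, the same kind of lengthening of the chain, is a 2.6-fold lower number from compound 1 to compound 2 (0.42 log units; beyond the scatter). On that single precedent compound 3 is expected to move a modest step lower again, a 1.7-fold lower number from compound 2 to compound 3 (0.23 log units; within the scatter), though with real uncertainty. The estimate for compound 3 is 4500 nM, ranging from 1800 nM to 14000 nM.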

Compound 3, half-maximal inhibitory concentration: 4100 nM
Beside the measured number, compound 3's estimate is 1.1-fold (0.04 log units) above it, and the stated range covers the measured number.
By their numbers in this assay, from the lowest: compounds 3 and 2 (each within the scatter of the next); then compound 1.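

In this assay, adding one more carbon at this place gives a 1.9-fold lower number from compound 2 to compound 3 (0.27 log units; within the scatter), a step that cannot be told apart from repeat measurement on its own. Going by these compounds alone, the change shows up only over the longer span, where 2-phenoxyethyl in place of phenoxy gives a 4.8-fold lower number from compound 1 to compound 3 (0.68 log units; beyond the scatter), so the three compounds are consistent with a drift toward lower numbers as the chain grows, with no compound going against it. Nothing available accounts for this drift.

Going by these compounds, whether a still longer chain would extend the drift stays open. So does how an amine or a carboxylic acid in place of the phenoxy would read out here.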